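This account rests on a few compounds, and the source may have more. Where it says the series, first, only, none or still open, it means among the compounds named here.

Compound 1 `O/N=C(/Nc1cccc(Br)c1)c1ccc2occc2c1`: 1100 nM
Compound 2 `O/N=C(/Nc1ccc(F)c(Br)c1)c1ccc2occc2c1`: 2600 nM
Compound 3 `O=C(NCc1ccccc1)c1cccc(N/C(=N/O)c2ccc3occc3c2)c1`: a limit of the assay, > 30000 nM

In an assay on tissue (HeLa cells) for inhibition of Indoleamine 2,3-dioxygenase 1 (Homo sapiens), read by spectrophotometry (on this read-out lower numbers stand for stronger inhibition and higher numbers for weaker inhibition), compound 1 holds the lowest of the two numbers given. Within the data shown here, the one measured step, a 2.4-fold higher number from compound 1 to compound 2 (0.37 log units; beyond the scatter), is modest. Compound 3 returns only a limit, (the limit of > 30000 nM in this assay, at which 1 of the 3 values shown sits).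

Compound 4 `O/N=C(/Nc1cccc(COc2ccccc2)c1)c1ccc2occc2c1` differs from compound 1 by phenoxymethyl in place of bromo on an aromatic carbon. Among the measured compounds shown here, no measured step covers a change of this kind; the only measured step concerns a fluoro substituent and gives little guidance. Of the pair compound 1 and compound 3, the member carrying a larger group on the ring gives no number at all in this assay, which points toward a weaker result for compound 4. Compound 4 is therefore expected to give about 8000 nM (range 2500 nM to 30000 nM). That estimate corresponds to an expected 7.3-fold higher number from compound 1 to compound 4 (0.86 log units; beyond the scatter).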

Compound 4, half-maximal inhibitory concentration: > 30000 nM
Compound 4: a limit, no number; the forecaster's own chance of this, stated with the estimate: 25%; middle value at least 3.7-fold (0.57 log units) from the limit.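

Phenoxymethyl in place of bromo, on the aromatic carbon meta to a large group, gives an at least 27-fold higher number from compound 1 to compound 4 (1.43 log units; beyond the scatter), so this position does not accept every replacement of bromo in this assay. That step is far larger than the change with fluoro, a 2.4-fold higher number from compound 1 to compound 2 (0.37 log units; beyond the scatter). Compound 4 gives a limit of the assay and not a number, and it now stands with compound 3: the limit of > 30000 nM in this assay, at which 2 of the 4 values shown sit.

Still open, as far as these compounds go, is whether methoxy or an amine at this position keeps a number close to that of compound 1, and at what size of group the number is lost. The two limits give no order between compound 3 and compound 4.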